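Indoline amide in place of methylpiperazine at the limit

The source may hold more compounds than are shown below. What is called first, only, known or untested is meant among the compounds shown, and "the series" means these compounds.

Compound 1 `CN(Cc1ccccc1)C(=O)C1CCN(C(=O)c2ccc(S(C)(=O)=O)c([N+](=O)[O-])c2)CC1` in an assay on isolated protein for inhibition of vitamin D3 receptor (Homo sapiens), read by fluorescence polarization (on this read-out higher numbers stand for weaker inhibition and lower numbers for stronger inhibition), gives only the assay limit > 60000 nM.
Compound 2 `CN(Cc1ccccc1F)C(=O)C1CCN(C(=O)c2ccc(S(C)(=O)=O)c([N+](=O)[O-])c2)CC1` in this assay gives only the limit > 60000 nM.
Compound 3 `CN1CCN(C(=O)C2CCN(C(=O)c3ccc(S(C)(=O)=O)c([N+](=O)[O-])c3)CC2)CC1` in this assay gives only the limit > 60000 nM.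

Compound 3 therefore stands at the limit of > 60000 nM in this assay, at which 3 of the 3 values shown sit; no number sets it apart from the other two. The steps a step that the two limits leave unreadable from compound 1 to compound 2, a step that the two limits leave unreadable from compound 1 to compound 3 and a step that the two limits leave unreadable from compound 2 to compound 3 are all unreadable, so nothing on this carbonyl carbon has yet moved a value off the limit.

Compound 4 `CC1Cc2ccccc2N1C(=O)C1CCN(C(=O)c2ccc(S(C)(=O)=O)c([N+](=O)[O-])c2)CC1` differs from compound 3 by 2-methyl-2,3-dihydro-1H-indol-1-yl in place of 4-methylpiperazin-1-yl on a carbonyl carbon. The two steps that change the amine on this carbonyl carbon, from compound 1 to compound 3 and from compound 2 to compound 3, bear on it, but both are unreadable, so no direction can be drawn from them in this assay.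

Compound 4 is therefore expected to give 60000 nM, with a range from 20000 nM to 100000 nM. The estimate for compound 4 implies a step of a number no higher from compound 3 to compound 4 (the limit leaves the size open) in this assay, expected to stay within the scatter and most likely again only a limit.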

Compound 4, half-maximal inhibitory concentration: > 60000 nM
Compound 4 was reported as a limit; the forecaster's own chance of this, stated with the estimate: 80%; the middle value lies on the limit itself.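

The steps linking compound 4 with compound 1, compound 2 and compound 3 cannot be read, as all four compounds share one limit: the limit of > 60000 nM in this assay, at which 4 of the 4 values shown sit.

The compounds shown leave open whether any group on this carbonyl carbon can give a measurable number in this assay.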